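The compounds below may be only part of what the source reports. "The series", "measured", "known", "first", "only" and "open" are said of these compounds alone.

Compound 1 `CCOC(=O)C1=C(Nc2ccccc2)S/C(=C\c2ccccc2)C1=O` gives 20.3% in a functional assay on JAR cells (Homo sapiens) for inhibition, read by MTT assay, with a stated time of 72 h, tested at 10 uM; a higher number here means more inhibition at the concentration tested (going by the name of the read-out), a lower number less inhibition. Compound 2 `CCOC(=O)C1=C(Nc2ccccc2)S/C(=C\c2ccc([N+](=O)[O-])c(O)c2)C1=O` gives 51.2% there, and compound 3 `CCOC(=O)C1=C(Nc2ccc(Br)cc2)S/C(=C\c2ccc[nH]2)C1=O` gives 41.5%. Among these three numbers compound 3 stands second highest: compound 2 is nearest, its number higher by an amount within the usual scatter, while compound 1 lies furthest, lower by an amount beyond it. Compound 4 `CCOC(=O)C1=C(Nc2ccc(CC)cc2)S/C(=C\c2ccc[nH]2)C1=O` differs from compound 3 in one place, (ethyl in place of bromo on an aromatic carbon), on an aromatic carbon of a six-membered aromatic ring of carbon only, para to a large group. For the measured compounds named here, no measured pair shows this exchange, so compound 3 alone anchors the expectation, and a change no larger than the scatter is expected in this assay. The step is expected to read a number 3.5 percentage points lower from compound 3 to compound 4 (within the scatter). Compound 4 is thus estimated at 38%, between 22% and 54%.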

Compound 4, a percentage reported as inhibition, at one concentration (the size of the read-out at that concentration, not a potency): < 10%
Compound 4 ended at the assay's limit (the forecaster's own chance of this, stated with the estimate: 3%); at least 28 percentage points between middle value and limit.
By their numbers in this assay, from the lowest: compound 1; then compounds 3 and 2 (each within the scatter of the next). At a limit, below all of these: compound 4.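

In this assay, for the compounds shown here, this is the first change in a single place, and the step from bromo to ethyl on this aromatic carbon reads a number at least 31.5 percentage points lower from compound 3 to compound 4 (beyond the scatter). Compound 4 gives < 10%, which is a limit of the assay and not a number. The 4-bromophenyl to 4-ethylphenyl exchange alone therefore carries the reading down to that limit, and how far the step extends past its printed size cannot be told: the limit of < 10% in this assay, at which 1 of the 4 values shown sits.

The compounds shown leave open how chloro, an amine, a methoxy group or a longer chain would read at this place. They also leave open whether the same exchange would give a step of this size with another group on the rest of the core.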